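The source may report more compounds than this note shows. Statements on the series, on what has been measured and on what is new or still open speak of the compounds shown alone.

For the measured compounds named here, compound 3 `CC1(C)CCC(CN2CCN(c3ccc(C(=O)NS(=O)(=O)c4ccc(OCC5CCOC5)c([N+](=O)[O-])c4)c(Oc4cnc5[nH]ccc5c4)c3)CC2)=C(c2ccc(C(F)(F)F)cc2)C1` gives 4.4 nM in an assay on isolated protein for displacement of a labelled ligand from Apoptosis regulator Bcl-2 (Homo sapiens), with a stated time of 15 min (on this read-out higher numbers stand for weaker inhibition and lower numbers for stronger inhibition), and stands highest of the three numbers measured so far. Compound 1 `CC1(C)CCC(CN2CCN(c3ccc(C(=O)NS(=O)(=O)c4ccc(NCC5CCOCC5)c([N+](=O)[O-])c4)c(Oc4cnc5[nH]ccc5c4)c3)CC2)=C(c2ccc(C(F)(F)F)cc2)C1` gives 1.5 nM in this assay, and compound 2 `CN1CCC(CNc2ccc(S(=O)(=O)NC(=O)c3ccc(N4CCN(CC5=C(c6ccc(C(F)(F)F)cc6)CC(C)(C)CC5)CC4)cc3Oc3cnc4[nH]ccc4c3)cc2[N+](=O)[O-])C1` gives 2.4 nM. The step of a 2.9-fold higher number from compound 1 to compound 3 (0.47 log units; beyond the scatter) is modest yet beyond the scatter, whereas a 1.8-fold higher number from compound 2 to compound 3 (0.26 log units; within the scatter) and a 1.6-fold higher number from compound 1 to compound 2 (0.20 log units; within the scatter) both stay within it. Compound 4 `CC1(C)CCC(CN2CCN(c3ccc(C(=O)NS(=O)(=O)c4ccc(OCC5CCCOC5)c([N+](=O)[O-])c4)c(Oc4cnc5[nH]ccc5c4)c3)CC2)=C(c2ccc(C(F)(F)F)cc2)C1` differs from compound 3 in one place: oxan-3-yl in place of oxolan-3-yl on a saturated chain carbon bound to an oxygen on an aromatic ring. Going by the values given here, no measured step alters the ring on the oxygen-linked side, so nothing bears on it directly. Among the compounds with values here, the only measured exchange of one saturated ring for another, a 1.6-fold higher number from compound 1 to compound 2 (0.20 log units; within the scatter), sits on the amine-linked side and lies within the scatter, and the two oxygen-linked compounds, compound 2 and compound 3, also sit within the scatter of each other. The account therefore expects no step beyond the scatter in this assay, in either direction. That expectation amounts to a step of a 1.0-fold higher number from compound 3 to compound 4 (0.01 log units; within the scatter). Compound 4 is accordingly estimated at 4.5 nM, with a range from 2 nM to 10 nM.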

Compound 4, half-maximal inhibitory concentration: 3 nM
Compound 4: middle estimate off by 1.5-fold (0.18 log units), on the high side, and the stated range covers the measured number.
By their numbers in this assay, from the lowest: compounds 1, 2, 4 and 3 (each within the scatter of the next, the first and the last beyond it).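

Oxan-3-yl in place of oxolan-3-yl on a saturated chain carbon bound to an oxygen on an aromatic ring is the first exchange of one ring for another on the oxygen-linked side, and in this assay the step of a 1.5-fold lower number from compound 3 to compound 4 (0.17 log units; within the scatter) shows that this position tolerates the larger ring without a change beyond the scatter. Compound 4 also stays within the scatter of both amine-linked compounds, with a 1.3-fold higher number from compound 2 to compound 4 (0.10 log units; within the scatter) and a 2.0-fold higher number from compound 1 to compound 4 (0.30 log units; within the scatter), so the separation beyond the scatter seen for compound 3 does not carry over to compound 4. Nothing given here explains these steps.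

The compounds shown leave open how this position responds to a group that differs more from these two rings, such as a morpholine or a carboxylic acid. They also leave open whether an open chain without a ring would stay within the scatter of compound 4.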